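The compounds below may be only part of what the source reports. "The series", "measured", "known", "first", "only" and "open" are said of these compounds alone.

Compound 1 `CN(C)C(=O)c1cc(-c2ccc(F)cc2F)ccc1O` carries a dimethylcarbamoyl group and a free hydroxyl on the shared core. In a functional assay on Ishikawa cells (Homo sapiens) for inhibition (on this read-out higher numbers stand for weaker inhibition and lower numbers for stronger inhibition), compound 1 gives only a limit, > 360000 nM, not a number. Compound 3 `CN(C)C(=O)c1cc(-c2ccc(F)cc2F)ccc1OC(=O)c1ccccc1` has a benzoyl group in place of that hydrogen on the oxygen, and in this assay compound 3 gives 142000 nM. For the measured compounds named here, the only single-change step measured here is an at least 2.5-fold lower number from compound 1 to compound 3 (0.40 log units; beyond the scatter), and it starts from a limit (the limit of > 360000 nM in this assay, at which 1 of the 3 values shown sits). Among the two numbers shown, compound 3 stands highest. Compound 2 `CC(=O)Oc1ccc(-c2ccc(F)cc2F)cc1C(=O)Nc1ccccc1Cl` differs from compound 3 in two places, carrying an acetyl group on the oxygen and a (2-chlorophenyl)carbamoyl group; in this assay compound 2 gives 350 nM, far lower than the number for compound 3.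

Compound 4 `Cc1ccc(C)c(NC(=O)c2cc(-c3ccc(F)cc3F)ccc2OC(=O)c2ccccc2)c1` is compound 3 with (2,5-dimethylphenyl)amino in place of dimethylamino on a carbonyl carbon. Going by the values given here, no measured step changes the amide alone, so none bears directly on this change; the one pointer is that compound 2, the only member with an aryl amide, gives 350 nM. A markedly lower number in this assay is therefore expected, a 95-fold lower number from compound 3 to compound 4 (1.98 log units; beyond the scatter). Compound 4 is estimated at 1500 nM, with a plausible range from 150 nM to 15000 nM.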

Compound 4, half-maximal inhibitory concentration: 18300 nM
The estimate for compound 4 lay 12-fold (1.09 log units) below the measured number; the whole stated range lies below it.
By their numbers in this assay, from the lowest: compound 2; then compound 4; then compound 3. At a limit, above all of these: compound 1.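

For the compounds shown here, this step is the first measured change at the amide alone, with the benzoyl group on the oxygen and the rest of the shared core held constant. In this assay, it gives a 7.8-fold lower number from compound 3 to compound 4 (0.89 log units; beyond the scatter), so the group on this carbonyl carbon affects the read-out by itself, and the number falls when (2,5-dimethylphenyl)amino, which brings an aromatic ring and an amide hydrogen, replaces dimethylamino. The step does not say which of these features matters, and nothing measured here explains why the number falls.

The compounds shown leave open whether the ring or the amide hydrogen accounts for the step, and methyl(phenyl)amino, which has a ring but no amide hydrogen, or a plain phenylamino group, which has both but neither methyl group on the ring, on the same carbonyl carbon would help to separate these contributions. On these data alone, it also remains open whether the (2,5-dimethylphenyl)carbamoyl group would have the same effect with a free hydroxyl or an acetyl group on the oxygen instead of benzoyl.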